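The compounds below may be only part of what the source reports. "The series", "measured", "known", "first", "only" and "open" are said of these compounds alone.

Within the data shown here, compound 2 `CN(O)C(=O)NCCSc1nc2ccccc2s1` gives 90 nM in a functional assay for inhibition of Polyunsaturated fatty acid 5-lipoxygenase (Homo sapiens) (a higher number here means that more compound is needed for the effect, a lower number that less compound is needed), the second highest of the three numbers so far. Nearest stands compound 3 `CCOc1ccc2nc(SCCNC(=O)N(C)O)sc2c1`, which gives 110 nM in this assay; the step of a 1.2-fold higher number from compound 2 to compound 3 (0.09 log units; within the scatter) puts ethoxy in place of hydrogen on an aromatic carbon. Furthest stands compound 1 `CN(O)C(=O)CCSc1nc2cc(Cl)ccc2s1`, which gives 20 nM in this assay; it differs from compound 2 in its chain as well as in a chloro group, so the two values show only a gap. Compound 4 `CN(O)C(=O)NCCSc1nc2cc(Cl)ccc2s1` differs from compound 2 by chloro in place of hydrogen on an aromatic carbon. Among the measured compounds shown here, no measured step isolates chloro for hydrogen on this core; the sole substitution on an aromatic carbon stayed within the scatter. He therefore expects at most a modest lowering in this assay, leaning that way because compound 1 gives 20 nM. Compound 4 is estimated at 60 nM, between 25 nM and 150 nM, a step of a 1.5-fold lower number from compound 2 to compound 4 (0.18 log units; within the scatter).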

Compound 4, half-maximal effective concentration: 20 nM
Estimate against measurement, compound 4: 3.0-fold (0.48 log units) above, outside the stated range (below it).
By their numbers in this assay, from the lowest: compounds 1 and 4 (each within the scatter of the next); then compounds 2 and 3 (each within the scatter of the next).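

In this assay, chloro in place of hydrogen on this aromatic carbon gives the first step from compound 2 to pass the scatter, a 4.5-fold lower number from compound 2 to compound 4 (0.65 log units; beyond the scatter), whereas the ethoxy step, a 1.2-fold higher number from compound 2 to compound 3 (0.09 log units; within the scatter), did not. With chloro on the core, the exchange of chain end leaves the value in place, with no change at the digits printed from compound 1 to compound 4 (within the scatter), so the gap seen earlier between compound 1 and compound 2 matches the step for chloro alone. As far as these compounds go, whether fluoro, bromo, methyl or a nitrile on this carbon would match chloro remains open, as does the effect of a longer chain. Nothing available here accounts for the effect of chloro.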